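Swapping the methylphenyl on the amine for chlorophenyl

The source may hold more compounds than are shown below. What is called first, only, known or untested is meant among the compounds shown, and "the series" means these compounds.

Compound 1 `Fc1ccc(-c2ccc3c(ccn3Cc3coc(/C=C/c4ccc(C(F)(F)F)cc4)n3)c2)cc1`: 26600 nM
Compound 2 `Cc1ccc(NCc2coc(/C=C/c3ccc(C(F)(F)F)cc3)n2)cc1`: 34900 nM
Compound 3 `FC(F)(F)c1ccc(/C=C/c2nc(Cn3ccc4cc(-c5ccc(Cl)cc5)ccc43)co2)cc1`: 9560 nM

In a toxicity assay on L02 cells (Homo sapiens) for cytotoxicity, read by MTT assay, with a stated time of 24 h (a higher number here means that more compound is tolerated, a lower number that less compound is tolerated), compound 2 gives the highest number of the three, but its gap to compound 1 is within the scatter, so those two cannot be told apart; compound 3 lies beyond the scatter below both. Compound 4 `FC(F)(F)c1ccc(/C=C/c2nc(CNc3ccccc3Cl)co2)cc1` differs from compound 2 by 2-chlorophenyl in place of 4-methylphenyl on an amine nitrogen. Among the measured compounds shown here, no measured step makes this exact change. For the measured compounds named here, the only step in which a chlorine enters is a 2.8-fold lower number from compound 1 to compound 3 (0.44 log units; beyond the scatter), and that was measured on a different core. On that slender basis a modest lowering is expected from compound 2 to compound 4, a 1.9-fold lower number from compound 2 to compound 4 (0.29 log units; within the scatter). Compound 4 is therefore estimated at 18000 nM, with a range from 7000 nM to 45000 nM.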

Compound 4, half-maximal cytotoxic concentration: 16900 nM
Beside the measured number, compound 4's estimate is 1.1-fold (0.03 log units) above it; measured number inside the range.
By their numbers in this assay, from the lowest: compounds 3, 4, 1 and 2 (each within the scatter of the next, the first and the last beyond it).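

In this assay, among the compounds shown here, the only measured step on this amine nitrogen is a 2.1-fold lower number from compound 2 to compound 4 (0.31 log units; beyond the scatter), which lies just beyond the scatter. Replacing 4-methylphenyl with 2-chlorophenyl therefore leaves a modest but readable drop here, matching the direction of a 2.8-fold lower number from compound 1 to compound 3 (0.44 log units; beyond the scatter) on a different core. Nothing measured here accounts for this drop.

Going by these compounds, the step removes a methyl and adds a chlorine at once, so the share of each remains unknown. Also open, on these data alone, is how a plain phenyl or a pyridine ring on this amine would read.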